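One Amine Tail for Another: Estimating Compound 4

The compounds below may be only part of what the source reports. "The series", "measured", "known", "first", "only" and "open" are said of these compounds alone.

Measured so far in a functional assay on A549 cells (Homo sapiens) for cytotoxicity, read by MTT assay, with a stated time of 72 h; on this read-out higher numbers stand for weaker inhibition and lower numbers for stronger inhibition:
Compound 1 `CN(C)Cc1ccc2nc(NC(=O)N/N=C3\C(=O)Nc4ccc(F)cc43)sc2c1` gives 2310 nM.
Compound 2 `CC1CCN(Cc2ccc3nc(NC(=O)N/N=C/c4c[nH]c5ccccc45)sc3c2)CC1` gives 3580 nM.
Compound 3 `CC1CCN(Cc2ccc3nc(NC(=O)N/N=C4\C(=O)Nc5ccc(F)cc54)sc3c2)CC1` gives 3010 nM.

Compound 3 and compound 1 differ in one place, (dimethylamino in place of 4-methylpiperidin-1-yl on a saturated chain carbon bound to an aromatic carbon), and this gave a 1.3-fold lower number from compound 3 to compound 1 (0.11 log units; within the scatter). Compound 2 and compound 3 share nothing that can be counted as a single change; the difference between the two cores is not broken down here. Among the measured compounds shown here, compound 4 `CN(C)Cc1ccc2nc(NC(=O)N/N=C/c3c[nH]c4ccccc34)sc2c1` is compound 2 with dimethylamino in place of 4-methylpiperidin-1-yl on a saturated chain carbon bound to an aromatic carbon, the same change as the one from compound 3 to compound 1, at the same kind of place. From compound 2 to compound 4 in this assay a step of about a 1.3-fold lower number from compound 2 to compound 4 (0.11 log units; within the scatter) is expected, because the earlier step was a 1.3-fold lower number from compound 3 to compound 1 (0.11 log units; within the scatter), which lies within the scatter. Compound 4 is therefore estimated at 2800 nM, likely between 1400 nM and 5600 nM.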

Compound 4, half-maximal inhibitory concentration: 3300 nM
For compound 4 the middle estimate is 1.2-fold (0.07 log units) below the measured one; the measured number falls inside the stated range.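

In this assay, putting dimethylamino in place of 4-methylpiperidin-1-yl gave a 1.1-fold lower number from compound 2 to compound 4 (0.04 log units; within the scatter). Set beside the earlier step, the change reads alike on the two cores: the same change on two cores in this assay, a 1.3-fold lower number (0.11 log units; within the scatter) from compound 3 to compound 1 and a 1.1-fold lower number (0.04 log units; within the scatter) from compound 2 to compound 4, 1.2-fold (0.08 log units) apart, within the scatter of two such steps. This shows that the swap stayed within the scatter on both cores, so the two amine groups cannot be told apart here; it does not show that the change would stay this small on any further core, and steps this small cannot show that a real effect carries over.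

The compounds shown leave open what other groups on this saturated chain carbon would give, such as morpholine, pyrrolidine or a carboxylic acid. They also leave open whether the swap reads the same on other cells.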